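Swapping Isopentyloxy for Hexyl on a Shared Core

The compounds below may be only part of what the source reports. "The series", "measured", "known", "first", "only" and "open" are said of these compounds alone.

- compound 1 `CCCc1ccc(-c2c(C)[nH]c(=O)n2C)cc1`: 21500 nM
- compound 2 `Cc1[nH]c(=O)n(C)c1-c1ccc(OC(C)C)cc1`: 20400 nM
- compound 3 `Cc1[nH]c(=O)n(C)c1-c1ccc(OCCC(C)C)cc1`: 6600 nM

In a functional assay on brain (Rattus norvegicus, strain Wistar) for inhibition (a lower number here means a stronger inhibitor, a higher number a weaker inhibitor), compound 3 gives the lowest of the three numbers, 6600 nM, which makes it the strongest inhibitor measured so far. The next compound is compound 4 `CCCCCCc1ccc(-c2c(C)[nH]c(=O)n2C)cc1`, with hexyl in place of isopentyloxy on an aromatic carbon.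

Going by the values given here, no measured compound carries hexyl, so the evidence is indirect. Replacing propyl with isopropoxy gave a 1.1-fold lower number from compound 1 to compound 2 (0.02 log units; within the scatter), so that swap of a chain joined through carbon for one joined through oxygen changed little. Moving to the longer isopentyloxy gave a 3.3-fold lower number from compound 1 to compound 3 (0.51 log units; beyond the scatter) and a 3.1-fold lower number from compound 2 to compound 3 (0.49 log units; beyond the scatter), both modest. Hexyl matches isopentyloxy in heavy-atom count, so compound 4 is expected to keep most of that modest gain.

The expected result in this assay is a 1.1-fold lower number from compound 3 to compound 4 (0.04 log units; within the scatter), which means no real change. The estimate for compound 4 is 6000 nM, with an expected range of 2200 nM to 16000 nM.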

Compound 4, half-maximal inhibitory concentration: 9000 nM
Estimate against measurement, compound 4: 1.5-fold (0.18 log units) below; low and high end bracket the measured number.
By their numbers in this assay, from the lowest: compounds 3 and 4 (each within the scatter of the next); then compounds 2 and 1 (each within the scatter of the next).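

In this assay, hexyl in place of isopentyloxy gives a 1.4-fold higher number from compound 3 to compound 4 (0.13 log units; within the scatter), so at this position, with the heavy-atom count unchanged, replacing the chain that carries an oxygen with an all-carbon chain makes no readable difference. Going by these compounds alone, the earlier gains had been seen only with isopentyloxy, but the all-carbon chain also gives a 2.4-fold lower number from compound 1 to compound 4 (0.38 log units; beyond the scatter) and a 2.3-fold lower number from compound 2 to compound 4 (0.36 log units; beyond the scatter), so a modest gain over the shorter groups does not depend on having that oxygen. There is no independent evidence here to explain these results.

The compounds shown do not tell whether a longer chain, such as octyl, would lower the number further or whether the trend stops near hexyl. They also leave open what an amine or a carboxylic acid at the end of the chain would do.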